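Dimethylamino for methyl on the styryl ring

The source may report more compounds than this note shows. Statements on the series, on what has been measured and on what is new or still open speak of the compounds shown alone.

Compound 2 `Cc1ccc(/C=C/C(=O)c2sc(NC(=O)c3ccc(F)cc3)nc2C)cc1` gives 91.5% in an assay for inhibition of Polyunsaturated fatty acid 5-lipoxygenase (Homo sapiens), read by spectrophotometry, tested at 10 uM, in the presence of a further agent that is not named here; on this read-out higher numbers stand for more inhibition at the one concentration tested (going by the name of the read-out) and lower numbers for less inhibition. Among the three measured compounds it stands second highest: compound 3 `COc1ccc(C(=O)Nc2nc(C)c(C(=O)/C=C/c3ccc(C)cc3)s2)cc1` gives 100%, a gap within the scatter, while compound 1 `Cc1ccc(/C=C/C(=O)c2sc(NC(=O)c3ccccc3)nc2C)cc1` gives 75.1%, and the step of a number 16.4 percentage points higher from compound 1 to compound 2 (beyond the scatter) lies beyond the scatter. The change to compound 4 `Cc1nc(NC(=O)c2ccc(F)cc2)sc1C(=O)/C=C/c1ccc(N(C)C)cc1` is dimethylamino in place of methyl on an aromatic carbon. Among the compounds with values here, none of the measured steps concerns this place: a number 16.4 percentage points higher from compound 1 to compound 2 (beyond the scatter), a number 24.9 percentage points higher from compound 1 to compound 3 (beyond the scatter) and a number 8.5 percentage points higher from compound 2 to compound 3 (within the scatter) all alter a different aromatic carbon, so they give no direct guide. With compound 2 already near the top of the scale, the step of a number 1.5 percentage points lower from compound 2 to compound 4 (within the scatter) is expected to be small and within the scatter. Compound 4 is therefore estimated at 90%, between 75% and 100%.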

Compound 4, a percentage reported as inhibition, at one concentration (the size of the read-out at that concentration, not a potency): 70.2%
Compound 4: the middle estimate sits 19.8 percentage points above what was measured; measured number below the stated range.
By their numbers in this assay, from the lowest: compounds 4 and 1 (each within the scatter of the next); then compounds 2 and 3 (each within the scatter of the next).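

Within the data shown here, replacing 4-methylphenyl with 4-(dimethylamino)phenyl is the first measured change at this place, and in this assay it gives a number 21.3 percentage points lower from compound 2 to compound 4 (beyond the scatter). The place para to a large group is therefore not indifferent to what it carries, at least in this pair. Nothing measured here explains the drop.

Going by these compounds, whether it follows from the added nitrogen or from the larger group stays open, as does how a plain amino group, a hydroxyl or a chlorine would read at this place. On these data alone, it is also open whether dimethylamino would cost as much alongside the methoxy of compound 3.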